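Carboxyl position on the benzyl thioether of compound 2

The compounds below may be only part of what the source reports. "The series", "measured", "known", "first", "only" and "open" are said of these compounds alone.

Among the measured compounds shown here, compound 2 `COc1ccc(CCCCCCCCOc2ccc(CSCc3cccc(C(=O)O)c3)nc2/C=C/C(=O)O)cc1` gives, in a functional assay on the whole organism with Homo sapiens as the target, read by calcium flux (on this read-out higher numbers stand for weaker inhibition and lower numbers for stronger inhibition), a value of 131 nM, the lowest of the two numbers known; compound 1 `COc1ccc(CCCCCCCCOc2ccc(C[S+]([O-])c3cccc(C(=O)O)c3)nc2/C=C/C(=O)O)cc1` gives 3900 nM, and the step of a 30-fold lower number from compound 1 to compound 2 (1.47 log units; beyond the scatter) is the only measured one. Compound 3 `COc1ccc(CCCCCCCCOc2ccc(CSCc3ccccc3C(=O)O)nc2/C=C/C(=O)O)cc1` differs from compound 2 by 2-carboxyphenyl in place of 3-carboxyphenyl on a saturated chain carbon bound to a sulfur. For the measured compounds named here, no measured step touches this change, so the one known step offers no direct guide and the expected direction is open. Compound 3 is estimated at 300 nM, within 60 nM to 1500 nM, the expected step being a 2.3-fold higher number from compound 2 to compound 3 (0.36 log units; beyond the scatter).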

Compound 3, half-maximal inhibitory concentration: 710 nM
Compound 3: middle estimate off by 2.4-fold (0.37 log units), on the low side; the range from low to high includes it.
By their numbers in this assay, from the lowest: compound 2; then compound 3; then compound 1.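

Moving the carboxyl, with 2-carboxyphenyl in place of 3-carboxyphenyl on a saturated chain carbon bound to a sulfur, gives in this assay a 5.4-fold higher number from compound 2 to compound 3 (0.73 log units; beyond the scatter); with the atoms unchanged, their arrangement alone shifts the read-out. The group swap at this end of the molecule still leaves a 5.5-fold lower number from compound 1 to compound 3 (0.74 log units; beyond the scatter), so compound 3 lies between the other two. No supporting data explain the difference between these isomers.

Open, on these data alone, is whether the carboxylic acid is needed at all on this ring. Plain phenyl or a primary amide in its place would address that.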